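This account rests on a few compounds, and the source may have more. Where it says the series, first, only, none or still open, it means among the compounds named here.

Of the compounds shown here, three built on one shared core have been measured. Compound 1 `COc1c(OCCCCN2CCN(C)CC2)cc(O)c2c(=O)cc(-c3ccc(C)cc3)oc12` gives 5430 nM in a functional assay on B16 cells (Mus musculus) for cytotoxicity, read by MTT assay, with a stated time of 72 h; on this read-out lower numbers stand for stronger inhibition and higher numbers for weaker inhibition. Compound 2 `COc1c(OCCCCN2CCN(C)CC2)cc(O)c2c(=O)cc(-c3ccc(Cl)cc3)oc12` gives 2090 nM in this assay, and compound 3 `COc1c(OCCCCN2CCN(C)CC2)cc(O)c2c(=O)cc(-c3ccc([N+](=O)[O-])cc3)oc12` gives 2890 nM in this assay. Compound 3 thus holds the second highest of the three numbers: it lies close to compound 2, and its gap to compound 1 also falls within the scatter of this kind of measurement. Compound 4 `COc1ccccc1-c1cc(=O)c2c(O)cc(OCCCCN3CCN(C)CC3)c(OC)c2o1` has not yet been measured; it differs from compound 3 in a single place: 2-methoxyphenyl in place of 4-nitrophenyl on an aromatic carbon. The steps seen so far each swap one group for another on an aromatic carbon: a 2.6-fold lower number from compound 1 to compound 2 (0.41 log units; beyond the scatter), a 1.9-fold lower number from compound 1 to compound 3 (0.27 log units; within the scatter) and a 1.4-fold higher number from compound 2 to compound 3 (0.14 log units; within the scatter). Only one of them reached beyond the scatter, and that one was modest. None of them brings in a 2-methoxyphenyl, so the change to compound 4 is not directly covered. With the measured steps all small, the expected step is a 1.2-fold higher number from compound 3 to compound 4 (0.08 log units; within the scatter), which is no change beyond the scatter. Compound 4 is estimated at 3500 nM, with a range from 1200 nM to 10000 nM.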

Compound 4, half-maximal inhibitory concentration: 9300 nM
Compound 4: middle estimate off by 2.7-fold (0.42 log units), on the low side; measured number inside the range.
By their numbers in this assay, from the lowest: compounds 2, 3, 1 and 4 (each within the scatter of the next, the first and the last beyond it).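

In this assay, the 2-methoxyphenyl group on this aromatic carbon next to the ring oxygen gives the largest steps seen so far: a 3.2-fold higher number from compound 3 to compound 4 (0.51 log units; beyond the scatter) and a 4.4-fold higher number from compound 2 to compound 4 (0.65 log units; beyond the scatter). Both are modest, but they show that the group at this carbon can shift the number further than the exchanges among the 4-substituted phenyl groups did. Compound 1 goes against any simple rule that 2-methoxyphenyl is the poorer choice, with a 1.7-fold higher number from compound 1 to compound 4 (0.23 log units; within the scatter).

No measurement shown here explains these differences. On these data alone, what a 4-methoxyphenyl, a 2-chlorophenyl or an unsubstituted phenyl would give at this carbon stays open, and so does whether the methoxy group itself or its place on the phenyl ring accounts for the change.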